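The source may hold more compounds than are shown below. What is called first, only, known or untested is meant among the compounds shown, and "the series" means these compounds.

Compound 2, `CNC(=O)c1cc(C(=O)NC2CC2)cn(Cc2cccc3[nH]ccc23)c1=O`: 78 ug/mL
Compound 1, `CNC(=O)c1cc(C(=O)NCC(C)C)cn(Cc2ccccc2)c1=O`: 43 ug/mL

In a physicochemical assay for solubility (a higher number here means a more soluble compound, a lower number a less soluble compound), compound 2 stands at the top of the two numbers shown with 78 ug/mL, while compound 1 gives 43 ug/mL; the gap lies within the scatter, so the two cannot be told apart. Compound 3, `CNC(=O)c1cc(C(=O)NC2CC2)cn(Cc2cccc(C#N)c2)c1=O`, has not yet been measured. It differs from compound 2 in one place: 3-cyanophenyl in place of 1H-indol-4-yl on a saturated chain carbon bound to an aromatic nitrogen. Among the measured compounds shown here, no measured pair here reflects such a change, so the expectation rests on the two values alone. The expected step is a 1.1-fold lower number from compound 2 to compound 3 (0.05 log units; within the scatter), nothing beyond the scatter. For compound 3 the estimated value in this assay is 70 ug/mL, within 30 ug/mL to 160 ug/mL.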

Compound 3, solubility: >= 148 ug/mL
Compound 3: a limit, no number; the forecaster's own chance of this, stated with the estimate: 5%; at least 2.1-fold (0.32 log units) between middle value and limit.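

In this assay compound 3 gives >= 148 ug/mL, which is a limit of the assay and not a number. Putting 3-cyanophenyl in place of 1H-indol-4-yl on a saturated chain carbon bound to an aromatic nitrogen gives an at least 1.8-fold higher number from compound 2 to compound 3 (0.27 log units; that floor lies within the scatter); this first single-place step shows no drop, but its full size cannot be read. Compound 3 is the one compound shown that reaches a limit: the limit of >= 148 ug/mL in this assay, at which 1 of the 3 values shown sits.

Going by these compounds, the true value of compound 3 remains open. So does the outcome of replacing the nitrile on this ring with an amine or a carboxylic acid.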